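Replacing 4-cyanophenyl on the ether oxygen of compound 2

This account rests on a few compounds, and the source may have more. Where it says the series, first, only, none or still open, it means among the compounds named here.

In an ADME assay on microsomes from liver (Rattus norvegicus) for metabolic stability, read by HPLC, using NADPH, with stated times of 5 min and 60 min, tested at 10 uM (on this read-out lower numbers stand for slow clearance and higher numbers for fast clearance), compound 1 `Cn1cc(-c2cc(S(N)(=O)=O)ccc2Oc2ccccc2)c2cc[nH]c2c1=O` gives 1320 mL/min/kg and compound 2 `CCS(=O)(=O)Nc1ccc(Oc2ccc(C#N)cc2)c(-c2cn(C)c(=O)c3[nH]ccc23)c1` gives 81.7 mL/min/kg as the lower of the two numbers, a gap beyond the usual scatter. Compound 3 `CCS(=O)(=O)Nc1ccc(OC2CCN(C)CC2)c(-c2cn(C)c(=O)c3[nH]ccc23)c1` has not yet been measured. It differs from compound 2 in one place, on an oxygen on an aromatic ring, where 1-methylpiperidin-4-yl stands in place of 4-cyanophenyl (1-methylpiperidin-4-yl in place of 4-cyanophenyl on an oxygen on an aromatic ring). Going by the values given here, no measured pair shows what this exchange does, so any forecast is loose. The spread between compound 2 at 81.7 mL/min/kg and compound 1 at 1320 mL/min/kg argues for a wide range. A small upward change, not beyond the scatter, is expected, and the estimated step is a 1.5-fold higher number from compound 2 to compound 3 (0.17 log units; within the scatter) on this read-out. In this assay the estimated value for compound 3 is 120 mL/min/kg (range 40 mL/min/kg to 400 mL/min/kg), which awaits measurement.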

Compound 3, clearance: 80 mL/min/kg
For compound 3 the middle estimate is 1.5-fold (0.18 log units) above the measured one; low and high end bracket the measured number.
By their numbers in this assay, from the lowest: compounds 3 and 2 (each within the scatter of the next); then compound 1.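

In this assay, 1-methylpiperidin-4-yl in place of 4-cyanophenyl on an oxygen on an aromatic ring gives a 1.0-fold lower number from compound 2 to compound 3 (0.01 log units; within the scatter), so this read-out does not tell the two compounds apart. Going by these compounds alone, this is the first pair that isolates this position, and it shows that a six-membered aromatic ring of carbon bearing a nitrile and a non-aromatic ring with one hetero atom can stand here with clearance numbers within the scatter of each other. No measurement at hand explains this match.

Within the data shown here, with only this one exchange, it remains open whether other groups on this oxygen would leave the clearance number just as unchanged. A carboxylic acid, a primary amine or a longer chain in this place could test how far that holds.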